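The compounds below may be only part of what the source reports. "The series", "measured", "known", "first", "only" and "open" are said of these compounds alone.

Compound 1, `Cc1ccc(C(=O)Nc2nc(Cl)c3cn(CC(C)(C)C)nc3n2)cc1`, gives > 10000 nM in a functional assay on CHO cells for antagonist activity at adenosine receptor A2b (Homo sapiens), read by 33P incorporation, with a stated time of 20 min, in the presence of a further agent that is not named here; on this read-out lower numbers stand for stronger inhibition and higher numbers for weaker inhibition.
Compound 2, `CC(C)(C)Cn1cc2c(Cl)nc(NC(=O)c3ccccc3)nc2n1`, gives >= 10000 nM in this assay.

Both results are limits of this assay rather than numbers. The value of compound 1 is a limit, as stated in the limit of > 10000 nM in this assay, at which 1 of the 2 values shown sits. The value of compound 2 is likewise a limit, as stated in the limit of >= 10000 nM in this assay, at which 1 of the 2 values shown sits, so compound 2 stands at the edge of what this assay can report, with no number that sets it apart. Going by the values given here, the one measured step, a step that the two limits leave unreadable from compound 1 to compound 2, cannot be read, since both ends sit at a limit.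

Compound 3, `CC(C)(C)Cn1cc2c(Cl)nc(N)nc2n1`, differs from compound 2 by hydrogen in place of benzoyl on a nitrogen on an aromatic ring. Among the compounds with values here, no measured step bears directly on this change; the only comparison in hand, from compound 1 to compound 2, is unreadable. Compound 3 is therefore expected to remain near the same limit, a step that the limit leaves unreadable from compound 2 to compound 3. The estimate for compound 3 in this assay is 20000 nM, with a range from 5000 nM to 80000 nM.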

Compound 3, inhibition constant: > 10000 nM
Compound 3: only a limit was reported; the forecaster's own chance of this, stated with the estimate: 80%; the middle value is on the limit's open side.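

In this assay, going by these compounds alone, compound 3 gives > 10000 nM, which is a limit and not a number, so no step between compound 2 and compound 3 can be read. With all three values at limits, the compounds shown leave open which change to the shared core, if any, would give a readable number in this assay.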